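Exchanging the Heteroaryl Tail on a Desaturase Inhibitor Core

A few compounds are considered here, and "the series" means these few. Any claim that something is new, unique, unknown or untested is made for them only; others in the source may bear on it.

Measured compounds:
Compound 1 `FC(F)(F)c1ccccc1OC1CCN(c2ccc(-n3ccnc3)nn2)CC1`: 4 nM
Compound 2 `Oc1nnc(-c2ccc(N3CCC(Oc4ccccc4C(F)(F)F)CC3)nn2)s1`: 6.1 nM

Both compounds were tested in an assay on microsomes from liver for inhibition of acyl-CoA desaturase 1 (Rattus norvegicus); on this read-out higher numbers stand for weaker inhibition and lower numbers for stronger inhibition. Compound 1 gives 4 nM and compound 2 gives 6.1 nM. Among the measured compounds shown here, the only measured step, a 1.5-fold higher number from compound 1 to compound 2 (0.18 log units; within the scatter), lies within the scatter, so the two compounds cannot be told apart on this read-out, and compound 2 stands simply at the upper of two closely spaced numbers.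

Compound 3 `CC(C)(C)c1nnc(-c2ccc(N3CCC(Oc4ccccc4C(F)(F)F)CC3)nn2)o1` is not yet measured. It differs from compound 2 in one place: 5-(tert-butyl)-1,3,4-oxadiazol-2-yl in place of 5-hydroxy-1,3,4-thiadiazol-2-yl on an aromatic carbon. For the measured compounds named here, the single step known so far, from compound 1 to compound 2, also replaced the group at this position and produced no change beyond the scatter. Going by the values given here, with only that one small step to lean on, compound 3 is expected to stay close to compound 2, and the expected step of a 1.0-fold lower number from compound 2 to compound 3 (0.01 log units; within the scatter) is none beyond the scatter. The estimate for compound 3 in this assay is 6 nM, with a range from 2 nM to 20 nM.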

Compound 3, half-maximal inhibitory concentration: 980 nM
Beside the measured number, compound 3's estimate is 160-fold (2.21 log units) below it, and the stated range ends below it.
By their numbers in this assay, from the lowest: compounds 1 and 2 (each within the scatter of the next); then compound 3.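

At this position, not every five-membered aromatic ring with 3 hetero atoms is tolerated in this assay: 5-(tert-butyl)-1,3,4-oxadiazol-2-yl gives a far higher number than 5-hydroxy-1,3,4-thiadiazol-2-yl (a 160-fold higher number from compound 2 to compound 3 (2.21 log units; beyond the scatter)) and also than 1H-imidazol-1-yl (a 250-fold higher number from compound 1 to compound 3 (2.39 log units; beyond the scatter)). The closeness of compound 1 and compound 2 therefore does not extend to every group placed here. This change alters several things at once, including the ring's hetero atoms, the group on that ring and the loss of the hydrogen-bond donor, and no measurement at hand links the result to any one of them.

Which of these differences matters remains open. Placing a methyl or an amine on the oxadiazole ring, or tert-butyl on the thiadiazole ring, would help separate the ring from the group it carries.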